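The source may hold more compounds than are shown below. What is called first, only, known or untested is meant among the compounds shown, and "the series" means these compounds.

Within the data shown here, in a functional assay on SW-620 cells (Homo sapiens) for cytotoxicity, read by MTT assay, with stated times of 4 h and 72 h, tested at 2 uM (on this read-out lower numbers stand for stronger inhibition and higher numbers for weaker inhibition), compound 1 (`Cc1ccc(/C=C/C(=O)c2ccc(Nc3cc(C)nc4nc(SCc5nc6ccccc6[nH]5)nn34)cc2)cc1`) gives 1520 nM, the highest of the three numbers measured so far. Compound 2 (`Cc1cc(Nc2ccc(C(=O)/C=C/c3ccccc3F)cc2)n2nc(SCc3nc4ccccc4[nH]3)nc2n1`) gives 250 nM and compound 3 (`Cc1cc(Nc2ccc(C(=O)/C=C/c3ccc(-n4cccn4)cc3)cc2)n2nc(SCc3nc4ccccc4[nH]3)nc2n1`) gives 340 nM. These two stand within the scatter of each other, as a 1.4-fold higher number from compound 2 to compound 3 (0.13 log units; within the scatter) shows. Compound 4 (`Cc1cc(Nc2ccc(C(=O)/C=C/c3cccc(F)c3)cc2)n2nc(SCc3nc4ccccc4[nH]3)nc2n1`) has not been measured and differs from compound 1 in one place: 3-fluorophenyl in place of 4-methylphenyl on a double-bonded chain carbon bound to a double-bonded chain carbon. Among the measured compounds shown here, two measured steps bear on this change. One is a 6.1-fold lower number from compound 1 to compound 2 (0.78 log units; beyond the scatter), with 2-fluorophenyl entering at the same place, and the other is a 4.5-fold lower number from compound 1 to compound 3 (0.65 log units; beyond the scatter), with 1H-pyrazol-1-yl replacing the methyl. For the measured compounds named here, no measured compound carries 3-fluorophenyl, but a similar drop is expected in this assay. The expected step is a 4.8-fold lower number from compound 1 to compound 4 (0.68 log units; beyond the scatter). Compound 4 is estimated at 320 nM, within a range of 130 nM to 800 nM.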

Compound 4, half-maximal inhibitory concentration: 590 nM
The estimate for compound 4 lay 1.8-fold (0.27 log units) below the measured number; the range from low to high includes it.
By their numbers in this assay, from the lowest: compounds 2, 3 and 4 (each within the scatter of the next, the first and the last beyond it); then compound 1.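

In this assay the gain over 4-methylphenyl is not confined to 2-fluorophenyl, as 3-fluorophenyl also gives a lower number (a 2.6-fold lower number from compound 1 to compound 4 (0.41 log units; beyond the scatter)). Among these compounds, the two fluorophenyl groups are not interchangeable at this place (a 2.4-fold higher number from compound 2 to compound 4 (0.37 log units; beyond the scatter)), a difference the earlier compounds could not show, while 3-fluorophenyl and 4-(1H-pyrazol-1-yl)phenyl remain close (a 1.7-fold higher number from compound 3 to compound 4 (0.24 log units; within the scatter)). Nothing available explains the gap between the two fluorophenyl groups. Still open, as far as these compounds go, is whether the gain follows the fluorine or the loss of the methyl; 4-fluorophenyl and 3-methylphenyl at this place would separate the two.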